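A few compounds are considered here, and "the series" means these few. Any claim that something is new, unique, unknown or untested is made for them only; others in the source may bear on it.

Measured compounds:
compound 1 `CCC(CC)n1c(-c2ccc(OCc3c(-c4c(Cl)cccc4Cl)noc3C(C)C)cc2)nc2ccc(C(=O)O)cc21`: 5690 nM
compound 2 `CC(C)c1onc(-c2c(Cl)cccc2Cl)c1COc1ccc(-c2nc3ccc(C(=O)O)cc3n2C(C)C)cc1`: 3550 nM
compound 3 `CCC(CC)n1c(-c2ccc(OCc3c(-c4c(Cl)cccc4Cl)noc3C(C)C)cc2F)nc2ccc(C(=O)O)cc21`: > 10000 nM

In an assay on HEK-293T cells for antagonist activity at vitamin D3 receptor (Homo sapiens), read by a luciferase reporter, with a stated time of 24 h (on this read-out higher numbers stand for weaker inhibition and lower numbers for stronger inhibition), compound 1 gives 5690 nM and compound 2 gives 3550 nM, with a 1.6-fold lower number from compound 1 to compound 2 (0.20 log units; within the scatter). For compound 3 the read-out is > 10000 nM, a limit of this assay and not a number. Compound 3 therefore stands at the limit of > 10000 nM in this assay, at which 1 of the 3 values shown sits, above the other two values shown. Compound 4 `CCC(CC)n1c(-c2ccc(OCc3c(-c4c(Cl)cccc4Cl)noc3C(C)C)cc2Cl)nc2ccc(C(=O)O)cc21` differs from compound 3 by chloro in place of fluoro on an aromatic carbon. Going by the values given here, the only measured step touching this carbon is an at least 1.7-fold higher number from compound 1 to compound 3 (0.24 log units; that floor lies within the scatter), which ends in the limit and gives no number to carry forward, and no measured step exchanges chloro for fluoro. Compound 4 is thus expected to remain at or near the limit, with a step that the limit leaves unreadable from compound 3 to compound 4. Compound 4 is estimated at 15000 nM, between 5000 nM and 50000 nM.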

Compound 4, half-maximal inhibitory concentration: 1010 nM
Compound 4: the middle estimate sits 15-fold (1.17 log units) above what was measured; measured number outside the range, below it.
By their numbers in this assay, from the lowest: compound 4; then compounds 2 and 1 (each within the scatter of the next). At a limit, above all of these: compound 3.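

In this assay, the aromatic carbon ortho to a large group and meta to a large group now shows a change beyond the scatter: chloro in place of hydrogen gives a 5.6-fold lower number from compound 1 to compound 4 (0.75 log units; beyond the scatter). Chloro in place of fluoro gives an at least 9.9-fold lower number from compound 3 to compound 4 (0.99 log units; beyond the scatter), so the two halogens part clearly at this carbon. That step is only a floor, for the value of compound 3 is a limit: the limit of > 10000 nM in this assay, at which 1 of the 4 values shown sits.

Going by these compounds, whether a bromo, methyl or methoxy group on this carbon would follow chloro or fluoro stays open. Also open, on these data alone, is whether chloro acts the same with isopropyl in place of pentan-3-yl on the aromatic nitrogen.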